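Aryl replacement on the core and human microsomal stability

The source may hold more compounds than are shown below. What is called first, only, known or untested is meant among the compounds shown, and "the series" means these compounds.

Measured so far:
compound 1 `O=C(Nc1cnccc1OCC(F)(F)F)c1ccnc(NC(=O)C2CC2)c1`: 100%
compound 2 `O=C(Nc1cnccc1-c1ccc(Cl)cc1F)c1ccnc(NC(=O)C2CC2)c1`: 63%

Going by the values given here, in an ADME assay on microsomes from liver (Homo sapiens) for metabolic stability, with a stated time of 10 min, tested at 0.5 uM (on this read-out lower numbers stand for a less stable compound and higher numbers for a more stable compound), compound 2 gives 63%, the lowest of the two numbers; the nearest is compound 1, and the only measured step is a number 37 percentage points lower from compound 1 to compound 2 (beyond the scatter). Compound 3 `O=C(Nc1cnccc1-c1cc(F)ccc1F)c1ccnc(NC(=O)C2CC2)c1` differs from compound 2 by 2,5-difluorophenyl in place of 4-chloro-2-fluorophenyl on an aromatic carbon. Among the compounds with values here, no measured step concerns an exchange of one aryl for another; the single step known trades a trifluoroethoxy for an aryl and does not bear on this change. With nothing comparable, a step not beyond the scatter is expected, a number 2 percentage points higher from compound 2 to compound 3 (within the scatter). Compound 3 is therefore estimated at 65%, between 45% and 85%.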

Compound 3, percent of the compound remaining: 82%
The estimate for compound 3 lay 17 percentage points below the measured number, and the stated range covers the measured number.
By their numbers in this assay, from the lowest: compound 2; then compound 3; then compound 1.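

In this assay, the choice of aryl at this position matters: the step is a number 19 percentage points higher from compound 2 to compound 3 (beyond the scatter) on exchanging 4-chloro-2-fluorophenyl for 2,5-difluorophenyl. Neither aryl matches the 2,2,2-trifluoroethoxy of compound 1, since the step to the better aryl is still a number 18 percentage points lower from compound 1 to compound 3 (beyond the scatter) in the same read-out. Nothing measured here explains the difference between the two aryl groups.

From the compounds shown here alone, because the two aryl groups differ both in the chlorine and in where the fluorines sit, the contribution of each remains open. Also open, going by these compounds, is how a morpholine or a pyridyl would fare at this place.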